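The compounds below may be only part of what the source reports. "The series", "measured", "known", "first", "only" and "open" are said of these compounds alone.

In a functional assay on the whole organism for positive allosteric modulation, with Rattus norvegicus as the target (a higher number here means that more compound is needed for the effect, a lower number that less compound is needed), the measured compounds stand as follows.
Compound 1, `Cc1nn(C)c2c1C(c1ccccc1)=NCCN2`: 2.5 mg/kg.
Compound 2, `Cc1nn(C)c2c1C(c1ccccc1)=NCCN2CCCN(C)C`: > 10 mg/kg, which is a limit of the assay rather than a number.
Compound 3, `Cc1nn(C)c2c1C(c1ccccc1Cl)=NCCN2`: 2.5 mg/kg.

Compound 1 sits level with compound 3 at the digits shown, and the two lie within the scatter of each other: no change at the digits printed from compound 1 to compound 3 (within the scatter), with chloro in place of hydrogen on an aromatic carbon. The other measured step alters a different part of the shared core: an at least 4.0-fold higher number from compound 1 to compound 2 (0.60 log units; beyond the scatter), with 3-(dimethylamino)propyl in place of hydrogen on a nitrogen on an aromatic ring in a ring. For compound 2 the reading is a limit only, (the limit of > 10 mg/kg in this assay, at which 1 of the 3 values shown sits).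

Compound 4, `Cc1nn(C)c2c1C(c1cccc(C(F)(F)F)c1)=NCCN2`, is not yet measured. It differs from compound 1 by trifluoromethyl in place of hydrogen on an aromatic carbon. The step from compound 1 to compound 2 touches another site and ends in a limit, so it offers little guidance here. Compound 4 is expected to show no change at the digits printed from compound 1 to compound 4 (within the scatter) because no change at the digits printed from compound 1 to compound 3 (within the scatter) also placed a substituent on an aromatic carbon of the six-membered aromatic ring of carbon only and stayed within the scatter. The estimate for compound 4 in this assay is 2.5 mg/kg, within 1 mg/kg to 8 mg/kg.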

Compound 4, minimum effective dose: 0.63 mg/kg
Compound 4: middle estimate off by 4.0-fold (0.60 log units), on the high side; measured number outside the range, below it.
By their numbers in this assay, from the lowest: compound 4; then compounds 1 and 3 (each within the scatter of the next). At a limit, above all of these: compound 2.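

In this assay, this change shows that a substituent on the six-membered aromatic ring of carbon only can move the number beyond the scatter, and toward less compound being needed: trifluoromethyl in place of hydrogen on an aromatic carbon, meta to a large group, gives a 4.0-fold lower number from compound 1 to compound 4 (0.60 log units; beyond the scatter). The only earlier substitution on this ring, chloro, had left no measurable mark, with no change at the digits printed from compound 1 to compound 3 (within the scatter), so that step alone could have suggested that the ring tolerates change without responding to it. Within the data shown here, compound 4 now sets that reading aside and gives the series its first step beyond the scatter toward a lower number, whereas the only earlier step beyond the scatter, at a different site of the shared core, ran toward a higher one.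

The compounds shown leave open whether the gain belongs to trifluoromethyl itself or to its place on the ring, and whether a methoxy group, a nitrile or a single fluorine on the same carbon would give a similar number. Nothing measured among these compounds accounts for the step from compound 1 to compound 4.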